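Sulfur substituents: from 2-hydroxycyclopentyl to 2-(methylsulfanyl)ethyl

This account rests on a few compounds, and the source may have more. Where it says the series, first, only, none or still open, it means among the compounds named here.

In a functional assay on HT cells (Homo sapiens) for antiproliferative activity, read by fluorescence, with a stated time of 72 h (a lower number here means a stronger inhibitor of growth, a higher number a weaker inhibitor of growth), compound 1 `CC(C)c1n[nH]c2c(NCc3ccc(-c4ccccn4)cc3)nc(SCCO)nc12`, with 2-hydroxyethyl on the sulfur, gives 48 nM. Compound 2 `CC(C)c1n[nH]c2c(NCc3ccc(-c4ccccn4)cc3)nc(SCC(O)C(F)(F)F)nc12` gives 690 nM, and compound 3 `CC(C)c1n[nH]c2c(NCc3ccc(-c4ccccn4)cc3)nc(SC3CCCC3O)nc12` gives 567 nM. These last two values cannot be told apart, with a 1.2-fold lower number from compound 2 to compound 3 (0.09 log units; within the scatter). Compound 3 thus stands level with compound 2, and both lie far from compound 1. The two departures from 2-hydroxyethyl gave a 14-fold higher number from compound 1 to compound 2 (1.16 log units; beyond the scatter) and a 12-fold higher number from compound 1 to compound 3 (1.07 log units; beyond the scatter).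

Compound 4 `CSCCSc1nc(NCc2ccc(-c3ccccn3)cc2)c2[nH]nc(C(C)C)c2n1` is the next case, with 2-(methylsulfanyl)ethyl in place of 2-hydroxycyclopentyl on a sulfur. The ring of compound 3 is gone, and the ethyl chain of compound 1 returns, but without its hydroxyl. Within the data shown here, no measured step tests the loss of that hydroxyl, so only a partial return towards the value of compound 1 at 48 nM is expected, given the size of a 12-fold higher number from compound 1 to compound 3 (1.07 log units; beyond the scatter). The expected change is a 3.3-fold lower number from compound 3 to compound 4 (0.52 log units; beyond the scatter). For compound 4 the estimated value is 170 nM, with an expected range of 50 nM to 600 nM.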

Compound 4, concentration for 50% growth inhibition: 975 nM
Estimate against measurement, compound 4: 5.7-fold (0.76 log units) below, outside the stated range (above it).
By their numbers in this assay, from the lowest: compound 1; then compounds 3, 2 and 4 (each within the scatter of the next).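

In this assay, among these compounds, replacing hydroxy with methylsulfanyl on the ethyl chain gives a 20-fold higher number from compound 1 to compound 4 (1.31 log units; beyond the scatter), the first step at this position that removes hydroxy while keeping the two-carbon chain. The ethyl chain alone therefore does not restore the value of compound 1, since the step is large even with that chain kept. Compound 4 also stands level with the two hydroxy-bearing groups, with a 1.7-fold higher number from compound 3 to compound 4 (0.24 log units; within the scatter) and a 1.4-fold higher number from compound 2 to compound 4 (0.15 log units; within the scatter), so all three departures from 2-hydroxyethyl end in the same range. No measurement available here accounts for these steps.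

Still open, on these data alone, is whether an amine or a carboxylic acid at the end of the ethyl chain would come close to compound 1 at 48 nM in this assay. Also open, as far as these compounds go, is whether 3-hydroxypropyl, a longer chain with its hydroxy kept, would hold that value.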